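Iodo on the phenyl ring of compound 1: expected cytotoxicity

The source may hold more compounds than are shown below. What is called first, only, known or untested is meant among the compounds shown, and "the series" means these compounds.

Measured so far:
- compound 1, `O=C1c2ccc(O)c(O)c2C(=O)N1Cc1ccccc1`: "not determined" (no result reported)
- compound 2, `O=C1c2c(ccc(O)c2O)CN1Cc1ccc(F)cc1`: "not determined" (no result reported)
- compound 3, `O=C1c2c(ccc(O)c2O)CN1Cc1cccc(I)c1`: 6920 nM

In an ADME assay on HOS cells (Homo sapiens) for cytotoxicity (a lower number here means a stronger inhibitor, a higher number a weaker inhibitor), compound 1 gives "not determined" (no result reported), so no number stands for it, and the same holds for compound 2, which gives "not determined" (no result reported). Among the compounds with values here, the only number in this assay belongs to compound 3, which gives 6920 nM. Compound 3 carries a different core from compound 1 and compound 4, so its value can serve as a reference point only, not as a step.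

Compound 4, `O=C1c2ccc(O)c(O)c2C(=O)N1Cc1cccc(I)c1`, is compound 1 with one change: iodo in place of hydrogen on an aromatic carbon. Within the data shown here, with no number for compound 1 and no comparable pair measured, the size of the step in this assay cannot be taken from the series; no more than a change within the usual scatter is expected in either direction, with the iodo-bearing compound 3 as the nearest anchor.

Compound 4 is therefore expected to give about 7000 nM in this assay, with a range from 2000 nM to 25000 nM.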

Compound 4, half-maximal inhibitory concentration: 12000 nM
Estimate against measurement, compound 4: 1.7-fold (0.23 log units) below; the range from low to high includes it.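

In this assay compound 1 gives "not determined" (no result reported) and compound 4 gives 12000 nM so no step can be read between these two compounds. The compounds shown leave open how far the change from phenyl to 3-iodophenyl moves the value on the core of compound 1. No measured property bears on this result.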